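The source may hold more compounds than are shown below. What is called first, only, known or untested is meant among the compounds shown, and "the series" means these compounds.

Compound 1 `CC(=O)OCc1ccc2oc(=O)c(C(=O)Oc3cccc(Br)c3)cc2c1` stands lowest of the three compounds measured in a functional assay on HT-1080 cells (Homo sapiens), read by transwell migration, with a stated time of 24 h, tested at 0.1 uM (a lower number here means a stronger effect, a higher number a weaker effect of the compound at the concentration tested), where compound 1 gives 39.5%. Compound 2 `CC(=O)OCc1ccc2oc(=O)c(C(=O)Sc3ccccc3)cc2c1` gives 89.5%, and compound 3 `CC(=O)OCc1ccc2oc(=O)c(C(=O)Sc3cccc(Cl)c3)cc2c1` gives 76.5%. The steps of a number 50 percentage points higher from compound 1 to compound 2 (beyond the scatter) and a number 37 percentage points higher from compound 1 to compound 3 (beyond the scatter) are large, while the step of a number 13 percentage points lower from compound 2 to compound 3 (beyond the scatter) is modest; all three concern the group attached to the carbonyl carbon. Compound 4 `CCCCC(=O)OCc1ccc2oc(=O)c(C(=O)Oc3cccc(Br)c3)cc2c1` differs from compound 1 in another place: propyl in place of hydrogen on a saturated chain carbon bound to a carbonyl carbon. For the measured compounds named here, none of the measured steps touches this part of the molecule, so the data give no measure of what the change may do, and the expectation is a step of a number 0.5 percentage points higher from compound 1 to compound 4 (within the scatter), nothing beyond the scatter. Compound 4 is therefore expected to give 40%, within a range from 20% to 62%.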

Compound 4, a percentage reported as activity, at one concentration (the size of the read-out at that concentration, not a potency): 92.4%
The estimate for compound 4 lay 52.4 percentage points below the measured number; measured number above the stated range.
By their numbers in this assay, from the lowest: compound 1; then compound 3; then compounds 2 and 4 (each within the scatter of the next).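

Going from acetoxy to (butylcarbonyl)oxy gives a number 52.9 percentage points higher from compound 1 to compound 4 (beyond the scatter) in this assay and so shows that this place, untouched by the earlier steps, responds strongly to change. With the 3-bromophenoxy group held constant, the longer chain alone weakens the effect at the concentration tested. No measurement at hand explains this step.

Going by these compounds, what a propionyloxy group, with a chain of intermediate length, or an amine or a hydroxyl in place of the acetoxy group would give remains open. On these data alone, whether the same change would act alike on compound 2 also remains open.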